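The source may report more compounds than this note shows. Statements on the series, on what has been measured and on what is new or still open speak of the compounds shown alone.

Measured so far:
Compound 1 `N=C(N)Nc1cccc(C(=O)NNC(=O)NC(CC(=O)O)C(N)=O)c1` gives -2.42 in a physicochemical assay for lipophilicity; on this read-out lower numbers stand for lower lipophilicity and higher numbers for higher lipophilicity.
Compound 2 `N=C(N)Nc1cccc(C(=O)NNC(=O)CC(CC(=O)O)c2ccc(Cl)cc2)c1` gives 1.68 in this assay.

Compound 2 stands highest of these two numbers in this assay. Among the measured compounds shown here, its only neighbour is compound 1, whose value lies far below it, beyond the scatter. Compound 3 `N=C(N)Nc1cccc(C(=O)NNC(=O)CC(CC(=O)O)c2ccc(-c3ccccc3)cc2)c1` differs from compound 2 in one place: phenyl in place of chloro on an aromatic carbon. For the measured compounds named here, no measured pair shows this change, so its size is not known from the data. The expectation is a rise in this assay well beyond the scatter, of a number 1.22 log units higher from compound 2 to compound 3 (beyond the scatter). Compound 3 is accordingly estimated at 2.9, with a range from 2.3 to 3.5.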

Compound 3, partition coefficient: 2.8
The estimate for compound 3 lay 0.10 log units above the measured number, and the stated range covers the measured number.
By their numbers in this assay, from the lowest: compound 1; then compound 2; then compound 3.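

Phenyl in place of chloro on an aromatic carbon, para to a large group, gives a number 1.12 log units higher from compound 2 to compound 3 (beyond the scatter) in this assay, so the number at this position moves with this change. Among the compounds shown here, this is the only step so far between compounds that differ in one place, and it rests on a single pair. Nothing at hand accounts for its size. From the compounds shown here alone, it remains open whether a methyl group or a methoxy group at this position, or an amine or a carboxylic acid on the added phenyl, would move the number the same way.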